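Compound 1 to compound 4: a shorter hydroxycarbamoyl chain

The source may hold more compounds than are shown below. What is called first, only, known or untested is meant among the compounds shown, and "the series" means these compounds.

Measured in a functional assay on MDA-MB-231 cells (Homo sapiens) for inhibition, read by MTT assay, with a stated time of 72 h; a lower number here means a stronger inhibitor, a higher number a weaker inhibitor:
- compound 1 `CNC(=O)CCCCCCCn1nc(-c2cnc3[nH]ccc3c2)c2c(N)ncnc21`: 15800 nM
- compound 2 `Nc1nc2cc(-c3nn(CCCC(=O)NO)c4ncnc(N)c34)ccc2o1`: 19500 nM
- compound 3 `Nc1nc2cc(-c3nn(CCCCCCCCCC(=O)NO)c4ncnc(N)c34)ccc2o1`: > 50000 nM (a limit)

Compound 1, at 15800 nM, lies within the scatter of compound 2, at 19500 nM. Compound 3 gives > 50000 nM, which is a limit of this assay and not a number.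

Compound 4 `Nc1ncnc2c1c(-c1cnc3[nH]ccc3c1)nn2CCC(=O)NO` shares the core of compound 1 and differs in the chain: hydroxycarbamoyl in place of 5-(methylcarbamoyl)pentyl on a saturated chain carbon, two bonds along the chain from an aromatic nitrogen. Hydroxycarbamoyl replaces 5-(methylcarbamoyl)pentyl on a saturated chain carbon, two bonds along the chain from an aromatic nitrogen.

Going by the values given here, only one measured step bears on this: an at least 2.5-fold higher number from compound 2 to compound 3 (0.40 log units; beyond the scatter). It added chain length, whereas this change removes it, which points weakly towards a lower number. That step was measured on a different core, however, and both of its compounds end in hydroxycarbamoyl, unlike compound 1. Only a small move is therefore expected, and the estimated 1.3-fold lower number from compound 1 to compound 4 (0.12 log units; within the scatter) stays within the scatter. For compound 4 the estimated value is 12000 nM, with an expected range of 3500 nM to 45000 nM.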

Compound 4, half-maximal inhibitory concentration: > 150000 nM
Compound 4 gave a limit, no number (the forecaster's own chance of this, stated with the estimate: 20%); middle value at least 12-fold (1.09 log units) away from the limit.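

The change at this place is not neutral on the core of compound 1: the chain swap gives an at least 9.4-fold higher number from compound 1 to compound 4 (0.97 log units; beyond the scatter). Compound 4 stands at a limit of the assay and not at a number: the limit of > 150000 nM in this assay, at which 1 of the 4 values shown sits. The earlier step, on a different core, was an at least 2.5-fold higher number from compound 2 to compound 3 (0.40 log units; beyond the scatter), so a lengthened chain and this shortened chain, both ending in hydroxycarbamoyl, each gave a higher number, and chain length shows no single direction across these compounds.

This step alters the chain length and the end group together, so the compounds shown leave open which of the two carries it. On the core of compound 1, a methylcarbamoyl group on the short chain, a hydroxycarbamoyl group on a longer chain, or a carboxylic acid at the chain end would begin to separate them.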